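From 3-Methoxyphenyl to 2-Bromophenyl on the Thiourea-Type Nitrogen

The source may hold more compounds than are shown below. What is called first, only, known or untested is meant among the compounds shown, and "the series" means these compounds.

In a functional assay on HL-60 cells (Homo sapiens) for antiproliferative activity, read by sulforhodamine B assay, with a stated time of 72 h (a higher number here means a weaker inhibitor, a lower number a stronger inhibitor), compound 1 `S=C(N/N=C/c1ccc2ccccc2n1)Nc1cccc(Br)c1` gives 53800 nM and compound 2 `COc1cccc(NC(=S)N/N=C/c2ccc3ccccc3n2)c1` gives 71200 nM. Among the compounds with values here, compound 2 therefore stands level with its only measured neighbour, the step being a 1.3-fold higher number from compound 1 to compound 2 (0.12 log units; within the scatter), with methoxy in place of bromo on an aromatic carbon. The next compound is compound 3 `S=C(N/N=C/c1ccc2ccccc2n1)Nc1ccccc1Br`, and the change is 2-bromophenyl in place of 3-methoxyphenyl on an amide-type nitrogen. Within the data shown here, only the one measured step bears on this change, and it stays within the scatter. Among the measured compounds shown here, no measured compound carries the 2-bromophenyl group, so the evidence is thin. No step beyond the scatter is therefore expected in this assay. The expected step is a 1.4-fold lower number from compound 2 to compound 3 (0.15 log units; within the scatter). Compound 3 is estimated at 50000 nM, with an expected range of 20000 nM to 100000 nM.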

Compound 3, half-maximal inhibitory concentration: > 100000 nM
Compound 3 gave a limit, no number; the forecaster's own chance of this, stated with the estimate: 15%; middle value at least 2.0-fold (0.30 log units) away from the limit.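

In this assay compound 3 gives a limit and not a number: the limit of > 100000 nM in this assay, at which 1 of the 3 values shown sits. With 2-bromophenyl in place of 3-bromophenyl on the amide-type nitrogen the step is an at least 1.8-fold higher number from compound 1 to compound 3 (0.26 log units; that floor lies within the scatter), and with 2-bromophenyl in place of 3-methoxyphenyl it is an at least 1.4-fold higher number from compound 2 to compound 3 (0.14 log units; that floor lies within the scatter). The earlier pair changed only methoxy for bromo and stayed within the scatter, whereas this change of aryl group gives the first result that reaches the limit of the assay, although neither floor establishes a real loss of activity.

Going by these compounds, how far compound 3 truly lies from compound 1 and compound 2 remains open. Also open, on these data alone, is what an amine or a carboxylic acid on the aromatic ring, or a longer chain in place of these aryl groups, would do on this nitrogen.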